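The compounds below may be only part of what the source reports. "The series", "measured", "known", "first", "only" and "open" are said of these compounds alone.

Compound 2, with structure `CS(=O)(=NC(F)(F)F)c1ccccc1`, carries a methyl on its sulfinyl sulfur, and in a functional assay on HepG2 cells (Homo sapiens) for cytotoxicity, read by spectrophotometry, with a stated time of 6 h (a higher number here means that more compound is tolerated, a lower number that less compound is tolerated), compound 2 gives "not determined" (no result reported): no result was reported for it, so it offers no anchor of its own. Compound 3, with structure `O=S(=NC(F)(F)F)(c1ccccc1)c1ccccc1`, is the next step along this series. The change is phenyl in place of methyl on a sulfinyl sulfur, and the rest of the molecule stays as it was. With compound 2 unmeasured, the size and direction of this step in this assay cannot be drawn from the numbers; nothing shown here says whether replacing methyl with phenyl moves tolerance beyond the usual scatter in either direction. The nearest measured relative is compound 1, with structure `O=S(=NSC(F)(F)F)(c1ccccc1)c1ccccc1`, which shares both phenyl groups and differs only at the nitrogen substituent; in this assay compound 1 gives 1 ug/mL. On that footing, compound 3 is expected to give about 2 ug/mL, within a range of 0.5 ug/mL to 8 ug/mL, in this assay.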

Compound 3, minimum cytotoxic concentration: 200 ug/mL
Beside the measured number, compound 3's estimate is 100-fold (2.00 log units) below it; measured number outside the range, above it.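

In this assay the group on the sulfonamide nitrogen proves to be a strong lever: with both phenyl groups kept, trifluoromethyl in place of (trifluoromethyl)sulfanyl gives a 200-fold higher number from compound 1 to compound 3 (2.30 log units; beyond the scatter), so far more compound is tolerated. Among these compounds, until now, the single usable number could not show that a change at this one place moves the read-out so far. Nothing available explains why this change has so large an effect.

The step of phenyl in place of methyl on the sulfinyl sulfur cannot be read, as compound 2 has no number to set against compound 3. As far as these compounds go, it also remains open where other groups on the sulfonamide nitrogen, such as an acetyl or a longer chain like ethyl, would fall relative to these two compounds.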